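The source may hold more compounds than are shown below. What is called first, only, known or untested is meant among the compounds shown, and "the series" means these compounds.

Of the compounds shown here, two have been tested in a functional assay on KM12 cells (Homo sapiens) for antiproliferative activity; a lower number here means a stronger inhibitor of growth, a higher number a weaker inhibitor of growth. Compound 1 (`COc1ccc(-c2nc3ccccc3s2)cc1OC`) gives 74200 nM, and compound 2 (`COc1ccc(-c2nc3cc(F)ccc3s2)cc1`) gives 24600 nM, the lower number of the two, with a gap beyond the usual scatter. Compound 3 (`CCOc1cc(-c2nc3cc(F)ccc3s2)ccc1OC`) has not yet been measured. It departs from compound 2 by a single change: ethoxy in place of hydrogen on an aromatic carbon, ortho to a methoxy group and meta to a large group. Going by the values given here, no measured step isolates this change, so the evidence is thin. Among the compounds with values here, a moderate rise in the number, meaning weaker growth inhibition, is expected, resting on compound 1 at 74200 nM, the only measured compound carrying two methoxy groups. The expected step is a 1.6-fold higher number from compound 2 to compound 3 (0.21 log units; within the scatter). For compound 3 the estimated value is 40000 nM, with an expected range of 14000 nM to 100000 nM.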

Compound 3, concentration for 50% growth inhibition: 5420 nM
The estimate for compound 3 lay 7.4-fold (0.87 log units) above the measured number, outside the stated range (below it).
By their numbers in this assay, from the lowest: compound 3; then compound 2; then compound 1.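

Going by these compounds alone, in (this assay), ethoxy in place of hydrogen on an aromatic carbon, ortho to a methoxy group and meta to a large group, gives (a 4.5-fold lower number from compound 2 to compound 3 (0.66 log units; beyond the scatter)), the first step in this set that isolates a change in one place. It shows that this position accepts ethoxy on the core of compound 2 and that growth inhibition gains from it, something compound 1 could not show, as it differs from compound 2 in more than one place. Nothing at hand accounts for the gain.

On these data alone, what remains open is whether this gain is particular to ethoxy or would also appear with another group at this carbon, such as hydroxy, propoxy or an amine. As far as these compounds go, it is also open whether the same step would hold on a core without the fluorine of compound 2.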